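The compounds below may be only part of what the source reports. "The series", "measured", "known", "first", "only" and "open" are said of these compounds alone.

In a functional assay for inhibition, with Rattus norvegicus as the target (a higher number here means a weaker inhibitor, a lower number a stronger inhibitor), compound 1 (`C[C@@H](/N=c1\c(O)c(O)\c1=N/c1ccc(C#N)cc1)C(C)(C)C`) gives 370 nM; 24300 nM (2 entries) in two entries that lie far apart. Compound 2 (`CC(/N=c1\c(O)c(O)\c1=N/c1cccc(C#N)c1)C(C)(C)C`) gives 3050 nM and compound 3 (`CCC(CC)/N=c1\c(O)c(O)\c1=N/c1ccc(C#N)cc1`) gives 3340 nM and so stands level with compound 2 within the usual scatter. Compound 4 (`CC(C)/N=c1\c(O)c(O)\c1=N/c1ccc(C#N)cc1`) is still unmeasured and has isopropyl in place of pentan-3-yl on a double-bonded nitrogen. Going by the values given here, no measured pair shows what a single change does here, so the expected step is small: an estimated 1.0-fold higher number from compound 3 to compound 4 (0.02 log units; within the scatter) that stays within the scatter, in neither direction clearly. The range stays wide because the several entries of compound 1 in this assay, 370 nM; 24300 nM (2 entries) show how far repeats can differ. Compound 4 is expected at 3500 nM with an estimated range from 900 nM to 14000 nM.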

Compound 4, half-maximal inhibitory concentration: 13700 nM
Compound 4: the middle estimate sits 3.9-fold (0.59 log units) below what was measured, and the stated range covers the measured number.
By their numbers in this assay, from the lowest: compounds 2 and 3 (each within the scatter of the next); then compound 4.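

Going by these compounds alone, the swap of pentan-3-yl for isopropyl on the double-bonded nitrogen gives the first single-place comparison in this assay and shows a 4.1-fold higher number from compound 3 to compound 4 (0.61 log units; beyond the scatter). Here the group with 3 heavy atoms gives the weaker inhibitor, so the number can move with the group at this position. Within the data shown here, this modest step is only a single comparison, and repeats of one compound can lie much further apart: the several entries of compound 1 in this assay, 370 nM; 24300 nM (2 entries). As far as these compounds go, whether a cyclopropyl group, a longer chain or a chain ending in an amine on this nitrogen would give a lower number remains open.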